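This account rests on a few compounds, and the source may have more. Where it says the series, first, only, none or still open, it means among the compounds named here.

Working notes on the series around compound 1 `O=C(CCSc1nc2cc(Cl)ccc2o1)N1CCS(=O)(=O)C1`. In an ADME assay on microsomes from liver (Homo sapiens) for metabolic stability, read by LC-MS, using NADPH, with a stated time of 45 min, tested at 0.5 uM (on this read-out higher numbers stand for fast clearance and lower numbers for slow clearance), compound 1 gives 1.7 mL/min/g, the only numerical result in hand for this read-out. The other result recorded is a limit rather than a number. Compound 2 `CS(=O)(=O)C1CCN(C(=O)CCSc2nc3cc(Cl)ccc3o2)C1` is that case: in this assay compound 2 returns only a limit, < 0.4 mL/min/g, and the limit of < 0.4 mL/min/g in this assay, at which 1 of the 2 values shown sits, is all that can be said of it. Among the measured compounds shown here, no two measured compounds differ in a single place, so no measured step exists to calibrate any change. Compound 3 `O=C(CCSc1nc2cc(Cl)ccc2o1)N1CCCCC1` has not yet been run in this assay; against compound 1 it carries piperidin-1-yl in place of 1,1-dioxo-1,3-thiazolidin-3-yl on a carbonyl carbon. For the measured compounds named here, with no comparable measured step available, the expected step of a 2.6-fold higher number from compound 1 to compound 3 (0.42 log units; beyond the scatter) is taken to point toward faster clearance and to lie beyond the usual scatter. Compound 3 is estimated at 4.5 mL/min/g. For compound 3 the expected range runs from 1.5 mL/min/g to 12 mL/min/g.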

Compound 3, intrinsic clearance in a liver preparation (reported as CLH), per the amount of preparation that the assay uses: 10.7 mL/min/g
Beside the measured number, compound 3's estimate is 2.4-fold (0.38 log units) below it; measured number inside the range.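

In this assay, among the compounds shown here, exchanging the group on the carbonyl carbon now has a measured size, with a 6.3-fold higher number from compound 1 to compound 3 (0.80 log units; beyond the scatter), the first step that differs in one place. This position is therefore not silent on this read-out: piperidin-1-yl carries compound 3 toward faster clearance than 1,1-dioxo-1,3-thiazolidin-3-yl gives compound 1, although the exchange changes the ring size, the hetero atoms and the acceptor count all at once. No measured property in hand bears on this step.

Which of those differences carries the step remains open, and morpholin-4-yl or pyrrolidin-1-yl on the same carbonyl carbon would begin to separate them. Also open, as far as these compounds go, is whether the step keeps its size when the shared core is changed.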